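A few compounds are considered here, and "the series" means these few. Any claim that something is new, unique, unknown or untested is made for them only; others in the source may bear on it.

Of the compounds shown here, three have been measured in a functional assay on SK-OV-3 cells (Homo sapiens) for cytotoxicity, read by sulforhodamine B assay, with a stated time of 48 h; on this read-out higher numbers stand for weaker inhibition of growth and lower numbers for stronger inhibition of growth. Compound 1 `ClCc1cccc(Cn2cnc3ncnc(Cl)c32)c1` gives 10700 nM, compound 3 `ClCc1ccccc1Cn1cnc2ncnc(Cl)c21` gives 7580 nM, and compound 2 `ClCc1ccc(Cn2cnc3nc(Cl)nc(Cl)c32)cc1` gives 2340 nM, the lowest of the three numbers and the strongest inhibitor of growth shown; its nearest neighbour is compound 3 and the furthest is compound 1, both beyond the usual scatter. For the measured compounds named here, compound 1 and compound 3 differ from compound 2 in more than one place, so no single structural step between measured compounds can be read from them.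

Compound 4 `ClCc1ccc(Cn2cnc3ncnc(Cl)c32)cc1` has not yet been measured. It differs from compound 2 in one place: hydrogen in place of chloro on an aromatic carbon. Going by the values given here, compound 1 and compound 3, which also carry only a single chloro group on the shared core, give the weaker numbers, though each differs from compound 2 elsewhere as well. On that basis the step from compound 2 to compound 4 is expected to weaken inhibition, a 2.8-fold higher number from compound 2 to compound 4 (0.44 log units; beyond the scatter), by more than the scatter. Compound 4 is estimated to give 6500 nM in this assay, within a range of 2500 nM to 16000 nM.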

Compound 4, concentration for 50% growth inhibition: 11200 nM
The estimate for compound 4 lay 1.7-fold (0.24 log units) below the measured number, within the range that was stated.
By their numbers in this assay, from the lowest: compound 2; then compounds 3, 1 and 4 (each within the scatter of the next).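

Hydrogen in place of chloro on the aromatic carbon between two ring nitrogen atoms gives a 4.8-fold higher number from compound 2 to compound 4 (0.68 log units; beyond the scatter) in this assay, the first comparison in this series that isolates a single change. With the rest of the structure held constant, the chloro group at this position therefore goes with stronger inhibition of growth, and its loss moves the number beyond the scatter. Nothing among the data shown accounts for the size or direction of this step.

From the compounds shown here alone, whether an amine, a methoxy group or a bromo group on this carbon would give a number closer to that of compound 2 or that of compound 4 remains open. Going by these compounds, it is also open whether chloro at this position would have a similar effect in compound 1 and compound 3, which carry hydrogen there.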